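The source may report more compounds than this note shows. Statements on the series, on what has been measured and on what is new or still open speak of the compounds shown alone.

In a functional assay on SK-OV-3 cells (Homo sapiens) for cytotoxicity, read by spectrophotometry, with a stated time of 72 h (on this read-out higher numbers stand for weaker inhibition and lower numbers for stronger inhibition), compound 2 `COc1ccc(-c2cccc(=O)n2-c2cc(OC)c(OC)c(OC)c2)cc1` gives < 10 nM, which is a limit of the assay and not a number. It stands at the limit of < 10 nM in this assay, at which 1 of the 3 values shown sits. In the same assay, compound 3 `COc1ccc(-c2cccc(=O)n2-c2cc(OC)c(OC)c(OC)c2)cc1OC` gives 545 nM and compound 1 `COc1ccc(-c2cccc(=O)n2-c2cc(OC)c(OC)c(OC)c2)cc1OCc1ccccc1` gives 2310 nM.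

Compound 4 `COc1cc(-n2c(-c3cccc(F)c3)cccc2=O)cc(OC)c1OC` has not yet been measured. It differs from compound 2 by 3-fluorophenyl in place of 4-methoxyphenyl on an aromatic carbon, next to the ring nitrogen (3-fluorophenyl in place of 4-methoxyphenyl on an aromatic carbon). Within the data shown here, no measured step makes this exchange, but two large steps alter the same aromatic group: an at least 54-fold higher number from compound 2 to compound 3 (1.73 log units; beyond the scatter) and an at least 230-fold lower number from compound 1 to compound 2 (2.36 log units; beyond the scatter). In both, compound 2 holds the lower number, so its reading has so far not survived a change to this group. Neither step removes the methoxy group or introduces fluorine, so the size remains uncertain. On the evidence of an at least 54-fold higher number from compound 2 to compound 3 (1.73 log units; beyond the scatter), a large move to a higher number is expected in this assay. The expected step is an at least 40-fold higher number from compound 2 to compound 4 (1.60 log units; beyond the scatter). Compound 4 is estimated at 400 nM, with an expected range from 40 nM to 4000 nM.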

Compound 4, half-maximal inhibitory concentration: 472 nM
Estimate against measurement, compound 4: 1.2-fold (0.07 log units) below; the measured number falls inside the stated range.
By their numbers in this assay, from the lowest: compounds 4 and 3 (each within the scatter of the next); then compound 1. At a limit, below all of these: compound 2.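

In this assay, the exchange of the whole aromatic group at this position, rather than an addition to it, gives an at least 47-fold higher number from compound 2 to compound 4 (1.67 log units; beyond the scatter). So the low reading of compound 2 depends on the 4-methoxyphenyl group as it stands, and it is lost with 3-fluorophenyl just as it was with the added methoxy and benzyloxy groups of compound 3 and compound 1. The reading of compound 2 is a limit and not a number, which leaves the true size of this step open: the limit of < 10 nM in this assay, at which 1 of the 4 values shown sits.

The exchange removes the methoxy group and brings in fluorine in one move, and the compounds shown do not separate these two changes. As far as these compounds go, how a plain phenyl, a 4-ethoxyphenyl or a phenyl carrying a dimethylamino group would read at this position remains open.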